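A few compounds are considered here, and "the series" means these few. Any claim that something is new, unique, unknown or untested is made for them only; others in the source may bear on it.

Compound 1 `COc1ccc(C(=O)/C=C/c2ccc(C(=O)Nc3cc([N+](=O)[O-])ccc3O)cc2)c(O)c1` was examined in an ADME assay on SH-SY5Y cells (Homo sapiens) for cytotoxicity, read by MTT assay, with a stated time of 48 h; on this read-out lower numbers stand for stronger inhibition and higher numbers for weaker inhibition. In this assay compound 1 gives > 100000 nM, which is a limit of the assay and not a number. Two further compounds were measured alongside it. Compound 2 `COc1ccc(C(=O)/C=C/c2cc(Br)c(OCc3ccccc3)c(OC)c2)c(O)c1` gives in this assay > 100000 nM, again a limit. Compound 3 `CCCCCCCCCCCCNC(=O)c1ccc(/C=C/C(=O)c2ccc(OC)cc2O)cc1` gives in this assay > 100000 nM, also a limit. Among the compounds with values here, compound 1 therefore stands together with the others at the limit of > 100000 nM in this assay, at which 3 of the 3 values shown sit; none of the three values is a number, and no step between measured compounds can be read from them. Compound 4 `CCCNC(=O)c1ccc(/C=C/C(=O)c2ccc(OC)cc2O)cc1` differs from compound 1 in one place: propyl in place of 2-hydroxy-5-nitrophenyl on an amide-type nitrogen. Nothing in the three shown values separates one structure from another, and no measured step is available to anchor the change. The step is expected to be a number no higher from compound 1 to compound 4 (the limit leaves the size open), that is, no change beyond the scatter. Compound 4 is estimated to give about 100000 nM in this assay, within a range from 30000 nM to 300000 nM, and most likely as a limit only.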

Compound 4, half-maximal inhibitory concentration: > 100000 nM
Compound 4: only a limit was reported; the forecaster's own chance of this, stated with the estimate: 80%; the middle value lies on the limit itself.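

No new step can be read from compound 1 to compound 4 or from compound 3 to compound 4, as both limits leave them unreadable: the limit of > 100000 nM in this assay, at which 4 of the 4 values shown sit. The compounds shown leave open whether any of these structures differs from another in this assay by a measurable amount.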